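This account rests on a few compounds, and the source may have more. Where it says the series, first, only, none or still open, it means among the compounds named here.

Measured in a functional assay on KB cells (Homo sapiens) for inhibition; on this read-out lower numbers stand for stronger inhibition of growth and higher numbers for weaker inhibition of growth:
Compound 1 `Cc1cccc(NC(=O)COc2ccc(/C=C3\SC(=O)NC3=O)cc2)n1` gives 75000 nM.
Compound 2 `O=C(COc1ccc(/C=C2\SC(=O)NC2=O)cc1)Nc1ccc([N+](=O)[O-])cc1` reaches only a limit, > 100000 nM.
Compound 3 `O=C(COc1ccc(/C=C2\SC(=O)NC2=O)cc1)Nc1ccc(F)cc1` likewise reaches only a limit, > 100000 nM.

Compound 3 thus stands at the limit of > 100000 nM in this assay, at which 2 of the 3 values shown sit, with no number of its own. Compound 4 `O=C(COc1ccc(/C=C2\SC(=O)NC2=O)cc1)Nc1ccc(Cl)cc1` differs from it by chloro in place of fluoro on an aromatic carbon. Within the data shown here, no measured step swaps one halogen for another; the nearest comparisons are a step that the two limits leave unreadable from compound 2 to compound 3 and an at least 1.3-fold higher number from compound 1 to compound 3 (0.12 log units; that floor lies within the scatter), neither of which fixes a size. With two of three values sitting at the limit, no step beyond the scatter in this assay is expected from compound 3 to compound 4. Compound 4 is estimated at 100000 nM, within 40000 nM to 250000 nM, most probably reported again only as a limit. The expected step of a number no higher from compound 3 to compound 4 (the limit leaves the size open) is taken to lie within the scatter.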

Compound 4, concentration for 50% growth inhibition: 50300 nM
Compound 4: the middle estimate sits 2.0-fold (0.30 log units) above what was measured, within the range that was stated.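

In this assay, chloro at this position, para to a large group, gives the series a phenyl compound with a number of its own, where compound 2 and compound 3 hold only a limit: the limit of > 100000 nM in this assay, at which 2 of the 4 values shown sit. The steps of an at least 1.9-fold lower number from compound 3 to compound 4 (0.29 log units; that floor lies within the scatter) and an at least 1.9-fold lower number from compound 2 to compound 4 (0.29 log units; that floor lies within the scatter) give floors only, and a 1.5-fold lower number from compound 1 to compound 4 (0.17 log units; within the scatter) leaves the 4-chlorophenyl and 6-methylpyridin-2-yl groups level. From the compounds shown here alone, whether bromo, methoxy or an amine at this position would give a step beyond the scatter stays open. So does the effect of a longer chain in place of the amide link.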